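Permeability notes: acetylpiperidine in place of methylsulfonylphenyl

A few compounds are considered here, and "the series" means these few. Any claim that something is new, unique, unknown or untested is made for them only; others in the source may bear on it.

Within the data shown here, compound 2 `Cn1cncc1CN1CC(N(Cc2ccc(S(C)(=O)=O)cc2)S(=O)(=O)c2ccccn2)Cc2cc(C#N)ccc21` gives 0.2 10^-6 cm/s in an ADME assay on Caco-2 cells (Homo sapiens) for permeability, in the apical to basolateral direction (a lower number here means that the compound crosses the layer more slowly, a higher number that the compound crosses the layer faster), the lowest of the two numbers measured so far; its nearest neighbour is compound 1 `CCC(=O)N1CCC(CN(C2Cc3cc(C#N)ccc3N(Cc3cncn3C)C2)S(=O)(=O)c2ccccn2)CC1`, which gives 0.5 10^-6 cm/s. Among the measured compounds shown here, the only measured step is a 2.5-fold lower number from compound 1 to compound 2 (0.40 log units; beyond the scatter), a modest step beyond the scatter. Compound 3 `CC(=O)N1CCC(CN(C2Cc3cc(C#N)ccc3N(Cc3cncn3C)C2)S(=O)(=O)c2ccccn2)CC1` is the next analogue to be measured. It differs from compound 2 by 1-acetylpiperidin-4-yl in place of 4-(methylsulfonyl)phenyl on a saturated chain carbon bound to a sulfonamide nitrogen. This change runs the measured step in reverse, the group entering being the acetyl counterpart of the 1-propanoylpiperidin-4-yl of compound 1. A higher number for compound 3 is expected because compound 1 gives 0.5 10^-6 cm/s in this assay. For compound 3 the step of a 2.0-fold higher number from compound 2 to compound 3 (0.30 log units; within the scatter) is expected. Compound 3 is therefore estimated at 0.4 10^-6 cm/s, with a range from 0.2 10^-6 cm/s to 0.9 10^-6 cm/s.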

Compound 3, apparent permeability: 0.5 10^-6 cm/s
For compound 3 the middle estimate is 1.3-fold (0.10 log units) below the measured one; the range from low to high includes it.
By their numbers in this assay, from the lowest: compound 2; then compounds 1 and 3 (each within the scatter of the next).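

With a second acylpiperidine on the saturated chain carbon bound to a sulfonamide nitrogen, 1-acetylpiperidin-4-yl in place of 4-(methylsulfonyl)phenyl gives a 2.5-fold higher number from compound 2 to compound 3 (0.40 log units; beyond the scatter) in this assay and so matches the size of the step seen earlier with 1-propanoylpiperidin-4-yl. Trimming the acyl group by one methyl gives no change at the digits printed from compound 1 to compound 3 (within the scatter) so the difference between acetyl and propanoyl does not register here, and both acylpiperidines stand apart from the methylsulfonylphenyl of compound 2. No available evidence bears on the origin of these steps.

Still open, from the compounds shown here alone, is whether a piperidine with a free amine in place of the amide would group with compound 1 and compound 3 or with compound 2. Also open, going by these compounds, is whether the same step holds with a methyl group in place of the aromatic ring on the sulfonamide sulfur.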